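Trimming an Acetamide to a Hydroxyl on a Shared Core

The source may hold more compounds than are shown below. What is called first, only, known or untested is meant among the compounds shown, and "the series" means these compounds.

Of the compounds shown here, three built on one shared core have been measured in a functional assay on blood for antagonist activity at thromboxane A2 receptor (Homo sapiens); a lower number here means tighter binding, a higher number weaker binding. Compound 1 `CC(=O)NCc1ccccc1-c1ccc(COC2CC[C@H](N3CCCCCC3)[C@H]2OC/C=C\CCC(=O)O)cc1` gives 25.1 nM. Compound 2 `NC(=O)Cc1ccccc1-c1ccc(COC2CC[C@H](N3CCCCCC3)[C@H]2OC/C=C\CCC(=O)O)cc1` gives 7.94 nM, and compound 3 `CC(=O)NCc1ccc(-c2ccc(COC3CC[C@H](N4CCCCCC4)[C@H]3OC/C=C\CCC(=O)O)cc2)cc1` gives 2.51 nM. Compound 3 thus stands lowest of the three: the step of a 3.2-fold lower number from compound 2 to compound 3 (0.50 log units; beyond the scatter) and the step of a 10-fold lower number from compound 1 to compound 3 (1.00 log units; beyond the scatter) both lie beyond the scatter, so compound 3 is the tightest binder among them.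

Compound 4 `O=C(O)CC/C=C\CO[C@H]1C(OCc2ccc(-c3ccc(CO)cc3)cc2)CC[C@@H]1N1CCCCCC1` has not yet been measured. It differs from compound 3 by hydroxy in place of acetamido on a saturated chain carbon bound to an aromatic carbon. Within the data shown here, no measured step exchanges exactly these two groups. The nearest guide is the step of a 3.2-fold lower number from compound 1 to compound 2 (0.50 log units; beyond the scatter), which changed a group on a saturated chain carbon bound to an aromatic carbon and moved the number modestly. That step shows the group on this carbon does matter, but it gives no direction for a hydroxy. Compound 4 is therefore expected to remain near compound 3, with a step of a 1.8-fold higher number from compound 3 to compound 4 (0.25 log units; within the scatter), and its value in this assay is estimated at 4.5 nM, within a range from 1.5 nM to 14 nM.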

Compound 4, dissociation constant: 3.16 nM
Compound 4: the middle estimate sits 1.4-fold (0.15 log units) above what was measured; low and high end bracket the measured number.
By their numbers in this assay, from the lowest: compounds 3 and 4 (each within the scatter of the next); then compound 2; then compound 1.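

On the saturated chain carbon bound to an aromatic carbon, the acetamido group can give way to a single hydroxy oxygen with no reading change in this assay, as a 1.3-fold higher number from compound 3 to compound 4 (0.10 log units; within the scatter) stays within the scatter. In this pair, then, the carbonyl and methyl of the acetamido group are not needed to keep the number low. The 4-(hydroxymethyl)phenyl group also keeps the advantage over the groups in the two weaker compounds, with a 2.5-fold lower number from compound 2 to compound 4 (0.40 log units; beyond the scatter) and a 7.9-fold lower number from compound 1 to compound 4 (0.90 log units; beyond the scatter). No supporting measurement bears on this result.

The compounds shown leave open how an amine or a carboxylic acid on this same carbon would read. They also leave open whether a longer chain ending in hydroxy, or a 2-(hydroxymethyl)phenyl group, would hold the number.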